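This account rests on a few compounds, and the source may have more. Where it says the series, first, only, none or still open, it means among the compounds named here.

Compound 1 `Cc1cnn(C(=O)N(C)CCN(C)Cc2cccc(OCc3ccccc3)c2)c1`: 9000 nM
Compound 2 `CN(CCN(C)C(=O)n1cccn1)Cc1cccc(OCc2ccccc2)c1`: 3000 nM

Both numbers come from an assay on membranes from brain for binding affinity to Fatty-acid amide hydrolase 1 (Mus musculus), read by fluorescence, with stated times of 1 h and 30 min; on this read-out higher numbers stand for weaker inhibition and lower numbers for stronger inhibition. Going by the values given here, compound 2 stands lowest of the two; its nearest neighbour is compound 1, reached through the single recorded change, a 3.0-fold lower number from compound 1 to compound 2 (0.48 log units; beyond the scatter), a hydrogen in place of a methyl on an aromatic carbon. Compound 3 `CN(CCN(C)C(=O)n1cc(C#N)cn1)Cc1cccc(OCc2ccccc2)c1` differs from compound 2 by cyano in place of hydrogen on an aromatic carbon. Among the compounds with values here, no measured step involves a cyano group, so that one recorded step is only a loose guide. For compound 3 the estimate is 1000 nM, with a range from 200 nM to 5000 nM. In this assay this means an expected step of a 3.0-fold lower number from compound 2 to compound 3 (0.48 log units; beyond the scatter).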

Compound 3, half-maximal inhibitory concentration: 190 nM
The estimate for compound 3 lay 5.3-fold (0.72 log units) above the measured number; measured number below the stated range.
By their numbers in this assay, from the lowest: compound 3; then compound 2; then compound 1.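

With cyano on this aromatic carbon, the number falls much further than it did when the methyl was lost, with a 16-fold lower number from compound 2 to compound 3 (1.20 log units; beyond the scatter) and a 47-fold lower number from compound 1 to compound 3 (1.68 log units; beyond the scatter) across the full swap. So this position does not simply favour having no group: methyl and cyano, placed on the same carbon, fall on opposite sides of hydrogen. No measurement at hand explains this difference between the two groups. The compounds shown leave open how a carboxylic acid, an amine or a chlorine atom on this carbon would read.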